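The source may report more compounds than this note shows. Statements on the series, on what has been measured and on what is new or still open speak of the compounds shown alone.

Measured so far in an ADME assay on microsomes from liver (Homo sapiens) for metabolic stability, with a stated time of 10 min; a higher number here means that more of the compound is left, a lower number that less of the compound is left:

- Compound 1 `CCC[C@]1(C(=O)N2CC[C@](c3ccc(C(F)(C(F)(F)F)C(F)(F)F)cc3)(S(=O)(=O)c3ccc(F)cc3)C2)CC[C@H](C(=O)O)CC1`: "not determined" (no result reported)
- Compound 2 `COC(=O)[C@H]1CC[C@H](C(=O)N2CC[C@](c3ccc(C(F)(C(F)(F)F)C(F)(F)F)cc3)(S(=O)(=O)c3ccc(F)cc3)C2)CC1`: "not determined" (no result reported)
- Compound 3 `O=C([C@H]1CC[C@H](CO)CC1)N1CC[C@](c2ccc(C(F)(C(F)(F)F)C(F)(F)F)cc2)(S(=O)(=O)c2ccc(F)cc2)C1`: 75%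

Only compound 3 has a number, so there is nothing to rank it against. It stands alone as the single reference point, and neither of the other two compounds can say whether its value is good or poor within this series.

The next compound to be tested is compound 4 `O=C(N1CC[C@](c2ccc(C(F)(C(F)(F)F)C(F)(F)F)cc2)(S(=O)(=O)c2ccc(F)cc2)C1)C1(CO)CCS(=O)(=O)CC1`. It keeps the rest of compound 3, but 4-(hydroxymethyl)-1,1-dioxothian-4-yl stands in place of 4-(hydroxymethyl)cyclohexyl on a carbonyl carbon: 4-(hydroxymethyl)-1,1-dioxothian-4-yl in place of 4-(hydroxymethyl)cyclohexyl on a carbonyl carbon.

Among the measured compounds shown here, no pair of measured compounds shows this change or any other, so the expectation is a judgement and not a trend read from data. With compound 3 at 75% in this assay, much of the compound is already left, which leaves limited room for a rise. A modest upward move is expected, not far beyond the usual scatter of repeat measurements. The estimated step is a number 10 percentage points higher from compound 3 to compound 4 (within the scatter). For compound 4 the expected value is 85%, with an estimated range of 68% to 98%.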

Compound 4, percent of the compound remaining: 75%
Beside the measured number, compound 4's estimate is 10 percentage points above it; measured number inside the range.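

In this assay, among the compounds shown here, putting 4-(hydroxymethyl)-1,1-dioxothian-4-yl in place of 4-(hydroxymethyl)cyclohexyl on a carbonyl carbon gives no change at the digits printed from compound 3 to compound 4 (within the scatter), which is the first comparison available in this set. The position therefore takes a larger group, with a sulfur in the ring, 3 hydrogen-bond acceptors instead of 1 and no defined stereocentres, without a detectable shift in the read-out, although this single step cannot show which of these differences matters or whether some of them offset one another. Nothing measured here offers an explanation for this result.

For the compounds shown here, the missing numbers for compound 1 and compound 2 mean that no steps involving their carboxylic acid or methyl ester can be read. The compounds shown also leave open whether the read-out would hold with an aminomethyl group in place of the hydroxymethyl, or with a six-membered ring containing a plain ring oxygen in place of the 1,1-dioxothian ring.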